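This account rests on a few compounds, and the source may have more. Where it says the series, first, only, none or still open, it means among the compounds named here.

Compound 1 `CN1C[C@H](C(=O)Nc2ccccc2)[C@@H](c2ccc(/C=C/C(=O)Nc3ccccc3N)cc2)C1` gives 7 mL/min/kg
Compound 2 `CN1C[C@H](C(=O)Nc2ccc(F)cc2)[C@@H](c2ccc(/C=C/C(=O)Nc3ccccc3N)cc2)C1` gives 5 mL/min/kg

In an in vitro ADME assay on microsomes from liver (Homo sapiens) for pharmacokinetics, read by LC-MS, with a stated time of 10 min, tested at 1 uM (on this read-out higher numbers stand for fast clearance and lower numbers for slow clearance), compound 2 gives 5 mL/min/kg and lies within the usual scatter of compound 1 at 7 mL/min/kg so the two numbers cannot be told apart. The next compound is compound 3 `Cc1ccc(NC(=O)[C@H]2CN(C)C[C@@H]2c2ccc(/C=C/C(=O)Nc3ccccc3N)cc2)cc1` and it differs from compound 2 in one place. The difference is methyl in place of fluoro on an aromatic carbon and in words it is methyl in place of fluoro on an aromatic carbon, para to a large group.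

Within the data shown here, only one measured step bears on this change. Fluoro in place of hydrogen on an aromatic carbon gave a 1.4-fold lower number from compound 1 to compound 2 (0.15 log units; within the scatter) and so stayed small. Among the measured compounds shown here, no compound carrying methyl has been measured, which makes this evidence indirect. Compound 3 is therefore expected to stay close to compound 2 at 5 mL/min/kg with no step beyond the scatter. The estimated step is a 1.2-fold higher number from compound 2 to compound 3 (0.08 log units; within the scatter) and no clear direction is expected. The estimated clearance of compound 3 is 6 mL/min/kg (estimated range 3 mL/min/kg to 13 mL/min/kg).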

Compound 3, clearance: 15 mL/min/kg
Estimate against measurement, compound 3: 2.5-fold (0.40 log units) below, outside the stated range (above it).
By their numbers in this assay, from the lowest: compounds 2 and 1 (each within the scatter of the next); then compound 3.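

In this assay the aromatic carbon para to a large group proves able to shift the clearance: methyl in place of fluoro gives a 3.0-fold higher number from compound 2 to compound 3 (0.48 log units; beyond the scatter) and is a modest step, and methyl in place of hydrogen gives a 2.1-fold higher number from compound 1 to compound 3 (0.33 log units; beyond the scatter) and is also modest. Until now this position had shown only the swap of hydrogen for fluoro, which stayed within the scatter, so it could have seemed indifferent to what sits there; now compound 3, with its methyl, stands apart from both compound 1 and compound 2, which still cannot be told apart from each other. Nothing measured here says why methyl behaves differently from hydrogen and fluoro.

The three compounds leave open whether the higher clearance belongs to methyl alone or would also appear with a larger group on the same carbon, such as ethyl, methoxy or trifluoromethyl. They also leave open whether chloro would stay with hydrogen and fluoro or move with methyl, and whether an amine or a carboxylic acid at this carbon would take the number in the other direction.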